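This account rests on a few compounds, and the source may have more. Where it says the series, first, only, none or still open, it means among the compounds named here.

In an ADME assay on MT4 cells (Homo sapiens) for cytotoxicity, read by MTT assay, with a stated time of 4 days (a lower number here means that less compound is tolerated, a higher number that more compound is tolerated), compound 1 `Cc1ccc(-c2c(C)c(-c3ccccc3)c(C(OC(C)(C)C)C(=O)O)c(C)c2NS(C)(=O)=O)cc1C` reaches only a limit, > 50000 nM. For the measured compounds named here, compound 2 `Cc1ccc(-c2c(C)c(-c3ccc(C)c(C)c3)c(C(OC(C)(C)C)C(=O)O)c(C)c2NS(C)(=O)=O)cc1C` gives 15000 nM, the only true number so far. Going by the values given here, the one measured step, an at least 3.3-fold lower number from compound 1 to compound 2 (0.52 log units; beyond the scatter), put 3,4-dimethylphenyl in place of phenyl on an aromatic carbon and lies beyond the scatter. Compound 3 `Cc1ccc(-c2c(C)c(-c3ccc(Cl)c(F)c3)c(C(OC(C)(C)C)C(=O)O)c(C)c2NS(C)(=O)=O)cc1C` changes that same place again, with 4-chloro-3-fluorophenyl in place of 3,4-dimethylphenyl (4-chloro-3-fluorophenyl in place of 3,4-dimethylphenyl on an aromatic carbon). Among the compounds with values here, no measured step tests this swap directly, so only a small change is expected, and the estimated step, a 1.1-fold lower number from compound 2 to compound 3 (0.03 log units; within the scatter), stays within the scatter. For compound 3 the expected value is 14000 nM, with an estimated range from 6000 nM to 35000 nM.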

Compound 3, half-maximal cytotoxic concentration: 22000 nM
For compound 3 the middle estimate is 1.6-fold (0.20 log units) below the measured one, within the range that was stated.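

Putting 4-chloro-3-fluorophenyl in place of 3,4-dimethylphenyl gives a 1.5-fold higher number from compound 2 to compound 3 (0.17 log units; within the scatter), so in this assay these two substituted rings cannot be told apart at this position. Against the plain phenyl, the second ring also gives an at least 2.2-fold lower number from compound 1 to compound 3 (0.35 log units; beyond the scatter), so the lower number is not tied to methyl groups alone. That step is only a bound, since compound 1 stands at a limit: the limit of > 50000 nM in this assay, at which 1 of the 3 values shown sits.

Still open, from the compounds shown here alone, is whether a single chlorine on the ring would be enough, and what an amine or a carboxylic acid there would do.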